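Hydroxy in Place of Amino: Expecting Compound 4

The source may report more compounds than this note shows. Statements on the series, on what has been measured and on what is new or still open speak of the compounds shown alone.

Measured so far:
Compound 1 `CCCc1cc(N)c2cc(NC(=O)/C=C/c3ccc(N)cc3)ccc2n1`: 190 nM
Compound 2 `CCCc1cc(NC2CCC2)c2cc(NC(=O)/C=C/c3ccc(C(F)(F)F)cc3)ccc2n1`: 18 nM
Compound 3 `Nc1cc(C2CCC2)nc2ccc(NC(=O)/C=C/c3ccc(C(F)(F)F)cc3)cc12`: 2 nM

In an assay on isolated protein for displacement of a labelled ligand from melanin-concentrating hormone receptor 1 (Homo sapiens) (a higher number here means a weaker inhibitor, a lower number a stronger inhibitor), compound 1 gives 190 nM, the highest of the three numbers. Compound 2 gives 18 nM in this assay, and compound 3 gives 2 nM; both lie well below compound 1, beyond the scatter, yet each differs from compound 1 in more than one place, so no single change can be read from those gaps.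

Compound 4 `CCCc1cc(N)c2cc(NC(=O)/C=C/c3ccc(O)cc3)ccc2n1` differs from compound 1 in one place only: hydroxy in place of amino on an aromatic carbon. Each of the two groups carries 1 hydrogen-bond donor and 1 hydrogen-bond acceptor, and the shared core is untouched. Among the compounds with values here, no measured pair isolates this exchange, so the implied step, a 1.1-fold lower number from compound 1 to compound 4 (0.05 log units; within the scatter), is expected to be small and to show no direction beyond the scatter. Compound 4 is therefore expected to give about 170 nM in this assay, within a range from 55 nM to 550 nM.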

Compound 4, half-maximal inhibitory concentration: 1100 nM
Estimate against measurement, compound 4: 6.5-fold (0.81 log units) below; the measured number lies above the stated range.
By their numbers in this assay, from the lowest: compound 3; then compound 2; then compound 1; then compound 4.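

In this assay the change from 4-aminophenyl to 4-hydroxyphenyl brings a 5.8-fold higher number from compound 1 to compound 4 (0.76 log units; beyond the scatter) and this is the only single-place step among the compounds shown. The amino and hydroxy groups have the same counts of hydrogen-bond donors and acceptors, so these counts alone do not settle the number at this position, on an aromatic carbon para to a large group. Nothing at hand explains why the two groups differ here.

The compounds shown leave open how a methoxy group, a dimethylamino group or a fluorine atom would compare with amino and hydroxy at this position. They also leave open whether the exchange of amino for hydroxy would bring a step of similar size on the shared core of compound 2 or compound 3.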